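Permeability notes on a two-compound aryl ether series

The source may hold more compounds than are shown below. What is called first, only, known or untested is meant among the compounds shown, and "the series" means these compounds.

Measured so far:
compound 1 `CNC(=O)c1cc(Oc2ccc3sc(Nc4cccc(C(C)(C)C)c4)nc3c2)ccn1` — 10 10^-6 cm/s
compound 2 `CCc1ccccc1Nc1nc2cc(Oc3ccnc(C(=O)NC)c3)ccc2o1` — 10 10^-6 cm/s

Both values come from an ADME assay on Caco-2 cells (Homo sapiens) for permeability, in the apical to basolateral direction; a lower number here means that the compound crosses the layer more slowly, a higher number that the compound crosses the layer faster. In this assay compound 1 gives 10 10^-6 cm/s and compound 2 gives 10 10^-6 cm/s; the two stand level at the digits shown, and no step beyond the scatter separates them. Among the measured compounds shown here, compound 1 is therefore neither ahead of nor behind its one measured neighbour.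

The next compound is compound 3 `CNC(=O)c1cc(Oc2ccc3sc(Nc4ccc(C(C)C)cc4)nc3c2)ccn1`. It differs from compound 1 in one place: 4-isopropylphenyl in place of 3-(tert-butyl)phenyl on a nitrogen on an aromatic ring. For the measured compounds named here, no step between measured compounds of this kind is available, so the expectation rests only on the standing of compound 1 at 10 10^-6 cm/s. The expected step is no change at the digits printed from compound 1 to compound 3 (within the scatter), which means none beyond the scatter in either direction. For compound 3 the estimated value is 10 10^-6 cm/s, with a range from 5 10^-6 cm/s to 20 10^-6 cm/s.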

Compound 3, apparent permeability: 10 10^-6 cm/s
Estimate against measurement, compound 3: no gap at the digits printed; the range from low to high includes it.
By their numbers in this assay, from the lowest: compounds 1, 2 and 3 (each within the scatter of the next).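

In this assay the series now has its first readable step, no change at the digits printed from compound 1 to compound 3 (within the scatter), with 4-isopropylphenyl in place of 3-(tert-butyl)phenyl on a nitrogen on an aromatic ring. For this one pair, then, exchanging one alkyl-substituted phenyl for another at this position leaves the read-out where it stood, which the earlier unpaired compounds could not show. Nothing on hand offers an explanation for this result.

Both groups compared are built of carbon only, so the compounds shown leave open how an aminomethyl group or a carboxylic acid on that phenyl ring would read in this assay. Also open, as far as these compounds go, is whether 4-isopropylphenyl on the core of compound 2 would give a similar value.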